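Shifting One Hydroxyl Group: What to Expect for Compound 4

This account rests on a few compounds, and the source may have more. Where it says the series, first, only, none or still open, it means among the compounds named here.

Three compounds have been measured in an assay on isolated protein for inhibition of Maltase-glucoamylase (Homo sapiens), with a stated time of 15 min; on this read-out higher numbers stand for weaker inhibition and lower numbers for stronger inhibition:
compound 1, `O=C(N/N=C\c1ccccn1)c1ccc(-c2nc3ccccc3s2)cc1`, 10200 nM
compound 2, `O=C(N/N=C/c1ccc(O)cc1)c1ccc(-c2nc3ccccc3s2)cc1`, 11300 nM
compound 3, `COc1ccc(/C=N/NC(=O)c2ccc(-c3nc4ccccc4s3)cc2)c(O)c1`, 6970 nM

Compound 3 gives the lowest of the three numbers, yet its gap to compound 1 and its gap to compound 2 both lie within the scatter, so none of the three can be called stronger or weaker than another. The two measured steps point the same way: a 1.1-fold higher number from compound 1 to compound 2 (0.04 log units; within the scatter), which exchanged the whole ring attached to the amide-type nitrogen, and a 1.6-fold lower number from compound 2 to compound 3 (0.21 log units; within the scatter), which put 2-hydroxy-4-methoxyphenyl in place of 4-hydroxyphenyl. Neither changed the number beyond the scatter.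

Compound 4, `COc1ccc(/C=N/NC(=O)c2ccc(-c3nc4ccccc4s3)cc2)cc1O`, keeps every atom of compound 3 and rearranges one ring: 3-hydroxy-4-methoxyphenyl in place of 2-hydroxy-4-methoxyphenyl on a carbon with a double bond to nitrogen. Among the compounds with values here, no measured step moves a hydroxyl group around a ring in this way, so the closest guide is the general picture that variation on this ring has so far left the read-out flat. A step within the scatter is therefore expected from compound 3 to compound 4, a 1.1-fold higher number from compound 3 to compound 4 (0.06 log units; within the scatter). Compound 4 is estimated at 8000 nM, with a likely range from 3500 nM to 18000 nM.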

Compound 4, half-maximal inhibitory concentration: "not active" (no number reported)
The entry for compound 4 holds no number; the estimate stays without a comparison.
By their numbers in this assay, from the lowest: compounds 3, 1 and 2 (each within the scatter of the next).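

In this assay, within the data shown here, compound 4 is reported as "not active" with no number, so no step from compound 3 to compound 4 can be read. No available evidence bears on this result. The compounds shown leave open how far 3-hydroxy-4-methoxyphenyl and 2-hydroxy-4-methoxyphenyl truly differ on this read-out.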